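A few compounds are considered here, and "the series" means these few. Any claim that something is new, unique, unknown or untested is made for them only; others in the source may bear on it.

The shared core appears in compound 1 `O=C(/C=C/c1cccc(NC(=O)c2ccccc2Cl)c1)c1nc2ccccc2[nH]1`, which in a functional assay on MCF7 cells (Homo sapiens) for antiproliferative activity, read by MTT assay, with a stated time of 48 h (a lower number here means a stronger inhibitor, a higher number a weaker inhibitor), gives 4570 nM. Compound 2 `O=C(Nc1cccc(/C=C/C(=O)c2nc3ccccc3[nH]2)c1)c1ccc(Cl)cc1` gives 8410 nM in this assay. Compound 3 `O=C(Nc1cccc(/C=C/C(=O)c2nc3ccccc3[nH]2)c1)c1cc(Cl)cc(Cl)c1` reaches only a limit of this assay, > 100000 nM. Of the two plain numbers, compound 2 holds the higher, yet the step of a 1.8-fold higher number from compound 1 to compound 2 (0.26 log units; within the scatter) stays within the scatter, so the two cannot be ranked. The other steps are large: an at least 21-fold higher number from compound 1 to compound 3 (1.34 log units; beyond the scatter) and an at least 11-fold higher number from compound 2 to compound 3 (1.07 log units; beyond the scatter) both run up to the limit (the limit of > 100000 nM in this assay, at which 1 of the 3 values shown sits).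

Compound 4 `Cc1ccccc1S(=O)(=O)Nc1cccc(/C=C/C(=O)c2nc3ccccc3[nH]2)c1` differs from compound 2 in one place: (2-methylphenyl)sulfonyl in place of (4-chlorophenyl)carbonyl on a nitrogen on an aromatic ring. The measured steps concern only the substituted phenyl on the carbonyl, where moving a single chlorine changed little and adding a second chlorine cost much. Going by the values given here, none of them exchanges the carbonyl for a sulfonyl or replaces chlorine by methyl, so they set no direct precedent; they show only that this side of the core tolerates some change and punishes other. The expectation for compound 4 is therefore a small loss with wide uncertainty, a step of a 1.8-fold higher number from compound 2 to compound 4 (0.25 log units; within the scatter) in this assay. Compound 4 is estimated at 15000 nM, within a range of 4000 nM to 70000 nM in this assay.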

Compound 4, half-maximal inhibitory concentration: 4130 nM
Compound 4: the middle estimate sits 3.6-fold (0.56 log units) above what was measured; low and high end bracket the measured number.
By their numbers in this assay, from the lowest: compounds 4, 1 and 2 (each within the scatter of the next, the first and the last beyond it). At a limit, above all of these: compound 3.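

In this assay, the nitrogen on the aromatic ring turns out to accept a (2-methylphenyl)sulfonyl group with no loss against the chlorinated benzoyl-type neighbours: the step is a 2.0-fold lower number from compound 2 to compound 4 (0.31 log units; beyond the scatter), modest in size, while a 1.1-fold lower number from compound 1 to compound 4 (0.04 log units; within the scatter) leaves compound 1 and compound 4 unranked. Going by these compounds alone, every earlier change kept the carbonyl and altered only the chlorine pattern, so this is the first sign that the carbonyl itself can be exchanged on this nitrogen while the number stays in the same range. The remaining step, an at least 24-fold lower number from compound 3 to compound 4 (1.38 log units; beyond the scatter), gives only a bound and no exact size, since compound 3 stands at a limit of the assay: the limit of > 100000 nM in this assay, at which 1 of the 4 values shown sits.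

The sulfonyl and the methyl enter together, so the compounds shown cannot tell which of the two accounts for the step, and a (4-chlorophenyl)sulfonyl group on the same nitrogen would separate them. They also leave open how an amine or a carboxylic acid on that phenyl ring, or a methylsulfonyl group with no ring at all, would behave in this assay.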